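A few compounds are considered here, and "the series" means these few. Any claim that something is new, unique, unknown or untested is made for them only; others in the source may bear on it.

Measured in an ADME assay for permeability, using PAMPA, with a stated time of 4 h, at pH 5.5; on this read-out higher numbers stand for higher permeability and lower numbers for lower permeability:
- compound 1 `NCCCCN(C[C@H]1Cc2ncccc2CN1)[C@H]1CCCc2cccnc21` gives 17 nm/s
- compound 2 `NCCCCN(C[C@@H]1Cc2nccnc2CN1)[C@H]1CCCc2cccnc21` gives 2 nm/s

Compound 1 at 17 nm/s stands highest of these two, and the gap down to compound 2 lies beyond the usual scatter. Compound 3 `NC(=O)NC/C=C\CN(C[C@H]1Cc2ncccc2CN1)[C@H]1CCCc2cccnc21` has not yet been measured. It keeps the core of compound 1 and changes one group (a group of 7 heavy atoms (4 carbon, 2 nitrogen, 1 oxygen; no ring) in place of a group of 4 heavy atoms (3 carbon, 1 nitrogen; no ring), on a saturated chain carbon bound to an amine nitrogen). Within the data shown here, no measured pair shows this change, so the data do not fix its size. The expected result is no shift beyond the scatter in either direction, an estimated small step (a 1.1-fold lower number from compound 1 to compound 3 (0.05 log units; within the scatter)). Compound 3 is expected at 15 nm/s (range 4 nm/s to 60 nm/s).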

Compound 3, apparent permeability: 5 nm/s
Compound 3: the middle estimate sits 3.0-fold (0.48 log units) above what was measured; the measured number falls inside the stated range.
By their numbers in this assay, from the lowest: compound 2; then compound 3; then compound 1.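

In this assay, the place on a saturated chain carbon bound to an amine nitrogen proves sensitive to the group it carries: putting a group of 7 heavy atoms in place of 3-aminopropyl gives a 3.4-fold lower number from compound 1 to compound 3 (0.53 log units; beyond the scatter). Among these compounds, this is the first measured change at this place, and the step is modest. Nothing measured here explains why the number falls.

On these data alone, the entering group differs in size, double bonds and hydrogen-bond donors all at once, so which difference matters stays open. Also open, as far as these compounds go, is how a carboxylic acid or a longer amine chain would read here.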